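Furan replaced by an ethoxy-hydroxyoxolane on the side chain

The source may hold more compounds than are shown below. What is called first, only, known or untested is meant among the compounds shown, and "the series" means these compounds.

In a functional assay on RAW264.7 cells (Mus musculus) for inhibition, read by Griess assay, with stated times of 2 h and 18 h (on this read-out higher numbers stand for weaker inhibition and lower numbers for stronger inhibition), compound 2 (`CC1=C(CCc2ccoc2)[C@@]2(C)CCCC(C)(C)[C@@H]2[C@H](O)C1=O`) gives > 50000 nM, a limit and not a number. Compound 1 (`CC1=C(CCc2ccoc2)[C@@]2(C)CC[C@@H](O)C(C)(C)[C@@H]2[C@H](O)C1=O`) is also a limit, at > 50000 nM. Compound 4 (`CCOC1CC(O)(CCC2=C(C)C(=O)[C@@H](O)[C@H]3C(C)(C)CCC[C@]23C)CO1`) arises from compound 2 by 5-ethoxy-3-hydroxyoxolan-3-yl in place of furan-3-yl on a saturated chain carbon, two bonds along the chain from a double-bonded ring carbon. For the measured compounds named here, the only measured step, a step that the two limits leave unreadable from compound 1 to compound 2, lies elsewhere on the core and gives no size to carry over. The nearest guide is compound 3 (`CCOC1CC(O)(CCC2=C(C)C(=O)C(O)=C3C(C)(C)C(=O)CC[C@]23C)CO1`), which bears the same 5-ethoxy-3-hydroxyoxolan-3-yl group on a different core and gives a true number, 22900 nM. On that basis, a modest move towards lower numbers is expected in this assay, which would mean stronger inhibition. The estimated change is an at least 1.7-fold lower number from compound 2 to compound 4 (0.25 log units; that floor lies within the scatter). For compound 4 the estimate is 28000 nM, with an expected range of 12000 nM to 50000 nM.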

Compound 4, half-maximal inhibitory concentration: > 50000 nM
Compound 4: no number, only a limit; the forecaster's own chance of this, stated with the estimate: 40%; at least 1.7-fold (0.25 log units) between middle value and limit.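

In this assay compound 2 and compound 4 are both limits, so no step between them can be read: the limit of > 50000 nM in this assay, at which 3 of the 4 values shown sit.

The compounds shown leave open whether 5-ethoxy-3-hydroxyoxolan-3-yl in place of furan-3-yl changes inhibition at all on the core of compound 2.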